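Replacing a Urea Linker with an Amide in a Cell Assay

This account rests on a few compounds, and the source may have more. Where it says the series, first, only, none or still open, it means among the compounds named here.

Of the compounds shown here, three sharing one core have been tested in a functional assay on RXF 393 cells (Homo sapiens) for inhibition, read by sulforhodamine B assay, with a stated time of 48 h, tested at 100 uM; on this read-out lower numbers stand for a stronger effect and higher numbers for a weaker effect at the one concentration tested. Compound 1 `COc1cc(Cl)cc(-c2nn(-c3cccc(NC(=O)Nc4ccc(Cl)c(C(F)(F)F)c4)c3)cc2-c2ccncc2)c1` gives -58%, compound 2 `COc1cc(Cl)cc(-c2nn(-c3cccc(NC(=O)Nc4ccc(Cl)c(Cl)c4)c3)cc2-c2ccncc2)c1` gives -43%, and compound 3 `COc1cc(Cl)cc(-c2nn(-c3cccc(NC(=O)Nc4cccc(C(F)(F)F)c4)c3)cc2-c2ccncc2)c1` gives -80%. Compound 3 thus stands lowest of the three, and on this read-out lowest means strongest: the two steps that lead to it are a number 22 percentage points lower from compound 1 to compound 3 (beyond the scatter) and a number 37 percentage points lower from compound 2 to compound 3 (beyond the scatter), both beyond the scatter. Compound 4 `COc1cc(Cl)cc(-c2nn(-c3cccc(NC(=O)c4cccc(C(F)(F)F)c4)c3)cc2-c2ccncc2)c1` is not yet measured. It differs from compound 3 by one change, (3-(trifluoromethyl)phenyl in place of (3-(trifluoromethyl)phenyl)amino on a carbonyl carbon). The urea linker of compound 3 becomes an amide, and one hydrogen-bond donor is lost. Within the data shown here, none of the measured steps touches the linker; all three, from a number 15 percentage points higher from compound 1 to compound 2 (beyond the scatter) through the two steps above, only change the substituents on the outer ring, and they show that such changes shift the number by modest to large amounts. The linker change is therefore untested here, and its direction can only be guessed. A modest loss of effect is expected, a number 25 percentage points higher from compound 3 to compound 4 (beyond the scatter), with wide uncertainty. Compound 4 is estimated at -55%, within a range from -90% to -10%.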

Compound 4, a percentage reported as activity, at one concentration (the size of the read-out at that concentration, not a potency): 19%
The estimate for compound 4 lay 74 percentage points below the measured number; measured number outside the range, above it.
By their numbers in this assay, from the lowest: compound 3; then compound 1; then compound 2; then compound 4.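

The linker proves far more sensitive than the outer ring in this assay: swapping (3-(trifluoromethyl)phenyl)amino for 3-(trifluoromethyl)phenyl on the carbonyl carbon gives a number 99 percentage points higher from compound 3 to compound 4 (beyond the scatter) and so exceeds even the largest outer-ring step among the ureas, which is a number 37 percentage points lower from compound 2 to compound 3 (beyond the scatter) in this set. The amide also sits well above the other two ureas, with a number 62 percentage points higher from compound 2 to compound 4 (beyond the scatter) and a number 77 percentage points higher from compound 1 to compound 4 (beyond the scatter) (both steps also alter the outer ring), and compound 4 at 19% is the only one of the four with a positive number. The change removes the amino nitrogen, and with it the 1 hydrogen-bond donor of the leaving group, but no measurement here explains why the number moves so far.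

The compounds shown leave open whether the nitrogen's hydrogen itself matters or the nitrogen atom as a link in the chain, a question that a methyl group on that urea nitrogen or a carbamate, with oxygen in its place, could address. Going by these compounds, whether the amide behaves the same way with a 4-chloro-3-(trifluoromethyl)phenyl or 3,4-dichlorophenyl outer ring also remains open.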